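The source may hold more compounds than are shown below. What is called first, only, known or untested is meant among the compounds shown, and "the series" means these compounds.

Three compounds have so far been measured in a functional assay on HCT-116 cells (Homo sapiens) for antiproliferative activity, read by CCK-8 assay, with a stated time of 72 h, tested at 2 uM; on this read-out higher numbers stand for a stronger effect at the one concentration tested and lower numbers for a weaker effect:

compound 1 `CN1CCN(c2nc(Cl)nc3c2ncn3Cc2ccc(C(=O)Nc3ccccc3N)cc2)CC1`: 71.6%
compound 2 `Nc1ccccc1NC(=O)c1ccc(CNc2nc(Cl)nc3c2ncn3Cc2ccccc2)cc1`: 7.7%
compound 3 `COC(CCn1cnc2c(NCc3ccc(C(=O)Nc4ccccc4N)cc3)nc(Cl)nc21)OC`: 6.39%

Compound 3 gives the smallest of the three numbers, but compound 2 sits within the scatter of it, so the two cannot be told apart; only compound 1 stands clearly above both. The three share a core, and compounds 2 and 3 differ from it in how the group on the aromatic nitrogen of the five-membered ring is made up.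

Compound 4 `CCC(C)n1cnc2c(NCc3ccc(C(=O)Nc4ccccc4N)cc3)nc(Cl)nc21` differs from compound 3 in one place: sec-butyl in place of 3,3-dimethoxypropyl on an aromatic nitrogen.

Among the compounds with values here, only one measured step concerns this same nitrogen, the step of a number 1.3 percentage points lower from compound 2 to compound 3 (within the scatter), and it is within the scatter. It exchanged a 2,2-dimethoxyethyl for a phenyl on a chain carbon bound to that nitrogen and left the number essentially where it was. Within the data shown here, no measured pair shows a sec-butyl at this place, so the new group has no direct precedent here. Given that the one comparable change made no visible difference, the expected step of a number 1.6 percentage points higher from compound 3 to compound 4 (within the scatter) is one of no size beyond the scatter. Compound 4 is therefore estimated to give about 8%, within a range from 0% to 25%.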

Compound 4, a percentage reported as inhibition, at one concentration (the size of the read-out at that concentration, not a potency): 74.6%
Compound 4: middle estimate off by 66.6 percentage points, on the low side; the measured number lies above the stated range.
By their numbers in this assay, from the lowest: compounds 3 and 2 (each within the scatter of the next); then compounds 1 and 4 (each within the scatter of the next).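

In this assay, the group on the aromatic nitrogen of the five-membered ring can matter a great deal: putting sec-butyl in place of 3,3-dimethoxypropyl gives a number 68.2 percentage points higher from compound 3 to compound 4 (beyond the scatter), and putting it in place of benzyl gives a number 66.9 percentage points higher from compound 2 to compound 4 (beyond the scatter). Within the data shown here, the earlier step, a number 1.3 percentage points lower from compound 2 to compound 3 (within the scatter), therefore showed only that those two groups could not be told apart, not that this position tolerates any change without effect. Sec-butyl has 4 heavy atoms and 0 hydrogen-bond acceptors where 3,3-dimethoxypropyl has 7 and 2, but nothing available links the large rise to either difference or offers any other explanation.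

The compounds shown leave open whether a straight butyl chain, an isopropyl or a cyclopentyl group on this nitrogen would give a number like that of compound 4 or one like that of compound 3. They also leave open whether a single methoxy group on a short chain at this place would be enough to bring the number down.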